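This account rests on a few compounds, and the source may have more. Where it says the series, first, only, none or still open, it means among the compounds named here.

Three compounds that differ only in the group on a double-bonded chain carbon bound to a double-bonded chain carbon have been measured in a functional assay on MCF7 cells (Homo sapiens) for antiproliferative activity, read by sulforhodamine B assay, with a stated time of 48 h; on this read-out higher numbers stand for weaker inhibition and lower numbers for stronger inhibition. Compound 1 (`COc1cccc(/C=C/C(=O)C(=Cc2ccc(F)cc2)C(=O)/C=C/c2cccc(OC)c2OC)c1OC`) gives 1830 nM, compound 2 (`COc1ccc(C=C(C(=O)/C=C/c2cccc(OC)c2OC)C(=O)/C=C/c2cccc(OC)c2OC)cc1OC`) gives 560 nM, and compound 3 (`COc1cc(OC)c(C=C(C(=O)/C=C/c2cccc(OC)c2OC)C(=O)/C=C/c2cccc(OC)c2OC)c(OC)c1`) gives 720 nM. Compound 3 therefore stands level with compound 2 and well clear of compound 1. The first gap is a 1.3-fold higher number from compound 2 to compound 3 (0.11 log units; within the scatter), and the second is a 2.5-fold lower number from compound 1 to compound 3 (0.41 log units; beyond the scatter).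

Compound 4 (`COc1cc(C=C(C(=O)/C=C/c2cccc(OC)c2OC)C(=O)/C=C/c2cccc(OC)c2OC)cc(Br)c1O`) has not yet been measured. It carries 3-bromo-4-hydroxy-5-methoxyphenyl in place of the 2,4,6-trimethoxyphenyl of compound 3: 3-bromo-4-hydroxy-5-methoxyphenyl in place of 2,4,6-trimethoxyphenyl on a double-bonded chain carbon bound to a double-bonded chain carbon.

Two kinds of measured step bear on this change. Leaving the 4-fluorophenyl of compound 1 for a methoxy-bearing ring gave modest steps, a 3.3-fold lower number from compound 1 to compound 2 (0.51 log units; beyond the scatter) and a 2.5-fold lower number from compound 1 to compound 3 (0.41 log units; beyond the scatter) already noted. Exchanging one methoxy-bearing ring for another gave only a 1.3-fold higher number from compound 2 to compound 3 (0.11 log units; within the scatter). Going by the values given here, compound 4 also has a methoxy-bearing ring, so the last of these is the closest guide, although no measured compound carries its bromine or hydroxy group. The estimated change is a 1.2-fold lower number from compound 3 to compound 4 (0.08 log units; within the scatter), a step expected to stay within the scatter. For compound 4 the expected value is 600 nM, with an estimated range from 250 nM to 1400 nM.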

Compound 4, half-maximal inhibitory concentration: 360 nM
Compound 4: the middle estimate sits 1.7-fold (0.22 log units) above what was measured; the range from low to high includes it.
By their numbers in this assay, from the lowest: compounds 4, 2 and 3 (each within the scatter of the next); then compound 1.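

The position on the double-bonded chain carbon accepts a ring carrying bromine and a hydroxy group as readily as the rings carrying only methoxy groups: in this assay, the exchange gives a 2.0-fold lower number from compound 3 to compound 4 (0.30 log units; within the scatter) and, against the other methoxy-only ring, a 1.6-fold lower number from compound 2 to compound 4 (0.19 log units; within the scatter), both within the usual scatter. The 3-bromo-4-hydroxy-5-methoxyphenyl group therefore cannot be told apart from the 3,4-dimethoxyphenyl or 2,4,6-trimethoxyphenyl groups here, even though it brings a hydrogen-bond donor that they lack, while the comparison with the fluorinated ring gives a 5.1-fold lower number from compound 1 to compound 4 (0.71 log units; beyond the scatter), beyond the scatter, so all three methoxy-bearing rings now stand clear of the 4-fluorophenyl of compound 1. No measurement shown here explains why these rings behave alike or why they differ from the 4-fluorophenyl group.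

Bromine and the hydroxy group enter together in compound 4, so the share of each remains unknown, as does the effect of the methoxy group that stays on that ring. On these data alone, how this position would respond to a ring bearing an amine or a carboxylic acid also remains open.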